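Half-life notes: swapping the amine substituent in compound 3

The source may report more compounds than this note shows. Statements on the series, on what has been measured and on what is new or still open speak of the compounds shown alone.

Three compounds in this series carry a number in an ADME assay on the whole organism (Mus musculus, strain ICR) for metabolic stability, read by HPLC, at a dose of 25 mg/kg by the oral route; a higher number here means that the compound lasts longer, a lower number that the compound disappears faster. In this assay compound 1 `O=c1nc(N2CCN(CC3CCCCC3)CC2)sc2c([N+](=O)[O-])cc(C(F)(F)F)cc12` gives 2.78 h. Compound 2 `CCc1nc2ccc(Cl)cn2c1C(=O)NCc1ccc(N2CCN(CC3CCCCC3)CC2)cc1` gives 2.75 h. Compound 3 `CCc1nc2ccc(Cl)cn2c1C(=O)NCc1ccc(N2CC3CN(CC4CCCCC4)CC3C2)cc1` gives 4.27 h. Compound 3 has the highest of the three numbers, but its gap to compound 1 and its gap to compound 2 both lie within the usual scatter, so the three sit together and none can be set apart from the others. For the measured compounds named here, no pair among them differs in only one place, so no single-point step is available to lean on.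

Compound 4 `CCc1nc2ccc(Cl)cn2c1C(=O)NCc1ccc(N2CC3CN(Cc4ccc(OC(F)(F)F)cc4)CC3C2)cc1` differs from compound 3 in one place: 4-(trifluoromethoxy)phenyl in place of cyclohexyl on a saturated chain carbon bound to an amine nitrogen in a ring. Nothing measured in the set speaks to this particular exchange, so the expectation rests only on the closeness of the three measured numbers. The step expected here is a 1.2-fold lower number from compound 3 to compound 4 (0.09 log units; within the scatter), which is to say none beyond the scatter is expected. Compound 4 is therefore estimated at 3.5 h, with a range from 1.5 h to 8 h.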

Compound 4, half-life: 5.23 h
Estimate against measurement, compound 4: 1.5-fold (0.17 log units) below; the range from low to high includes it.
By their numbers in this assay, from the lowest: compounds 2, 1, 3 and 4 (each within the scatter of the next).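

For the compounds shown here, the first single-point step falls at this position: a 1.2-fold higher number from compound 3 to compound 4 (0.09 log units; within the scatter) in this assay. The exchange therefore replaces a non-aromatic ring of carbon only with an aromatic one, adds a hydrogen-bond acceptor and raises the group from 6 to 11 heavy atoms, yet the half-life stays within the scatter. In this single pair, the place on a saturated chain carbon bound to an amine nitrogen in a ring accepts either group without a separable change in the number. Nothing at hand explains this result.

On these data alone, it remains open whether a plain phenyl, or a phenyl carrying a carboxylic acid or an amine, would also stay within the scatter at this place. Also open, as far as these compounds go, is whether the same exchange on compound 2 would read the same way.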